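Aryl exchange on sulfur in a low-inhibition pair

A few compounds are considered here, and "the series" means these few. Any claim that something is new, unique, unknown or untested is made for them only; others in the source may bear on it.

Two thioethers on the shared core have been measured so far in a functional assay on A-375 cells (Homo sapiens) for inhibition, read by CCK-8 assay, with a stated time of 72 h, tested at 2 uM; on this read-out higher numbers stand for more inhibition of growth at the one concentration tested and lower numbers for less inhibition of growth. Compound 1 `Cc1cc(C)cc(SCc2ccc(/C=C/C(=O)Nc3ccccc3N)cc2)c1` gives 8.78%, and compound 2 `Nc1ccccc1NC(=O)/C=C/c1ccc(CSc2cccc3ccccc23)cc1` gives 1.55%. These two numbers sit within the scatter of each other, so compound 2 stands level with compound 1, and both read as little inhibition of growth.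

The next compound, compound 3 `CC(C)(C)c1ccc(SCc2ccc(/C=C/C(=O)Nc3ccccc3N)cc2)cc1`, carries 4-(tert-butyl)phenyl in place of naphthalen-1-yl on a sulfur. Within the data shown here, only one measured step bears on this change, as it falls at the same sulfur: a number 7.2 percentage points lower from compound 1 to compound 2 (within the scatter). Among the measured compounds shown here, with only that small step as a guide, no change beyond the scatter is expected in this assay.

The expected step is a number 4.5 percentage points higher from compound 2 to compound 3 (within the scatter). For compound 3 the estimate is 6%, with an expected range of 0% to 18%.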

Compound 3, percent growth inhibition at one concentration: 38.4%
Estimate against measurement, compound 3: 32.4 percentage points below; the whole stated range lies below it.
By their numbers in this assay, from the lowest: compounds 2 and 1 (each within the scatter of the next); then compound 3.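

At the sulfur, the aryl group is not a neutral choice in this assay: 4-(tert-butyl)phenyl in place of naphthalen-1-yl gives a number 36.9 percentage points higher from compound 2 to compound 3 (beyond the scatter), and 4-(tert-butyl)phenyl in place of 3,5-dimethylphenyl gives a number 29.6 percentage points higher from compound 1 to compound 3 (beyond the scatter), whereas the earlier exchange at this sulfur stayed within the scatter. Naphthalen-1-yl and 4-(tert-butyl)phenyl carry the same count of heavy atoms, all carbon, so that count does not separate them, though they differ in aromatic rings, one against two. Nothing on hand accounts for the rise at this position.

Open, as far as these compounds go, is whether the level holds with a carboxylic acid or an amine in place of the tert-butyl group on the phenyl ring. Also open, from the compounds shown here alone, is what an oxygen in place of the sulfur would do on the shared core.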